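The source may report more compounds than this note shows. Statements on the series, on what has been measured and on what is new or still open speak of the compounds shown alone.

Working notes on the series.

Compound 1 `O=C(O)Cc1sc(C(c2ccc(F)cc2)c2ccc(F)cc2)nc1-c1ccnc(N2CCCC2)c1` is one of two compounds in the set with a reading in an in vitro functional assay on HEK285-7 cells for antagonist activity at prostaglandin D2 receptor 2 (Homo sapiens), read by BRET and beta-arrestin recruitment; on this read-out lower numbers stand for smaller maximal responses and higher numbers for larger maximal responses. In this assay compound 1 gives 80%. For the measured compounds named here, the other measured compound, compound 2 `O=C(O)Cc1sc(C(c2ccccc2)c2ccccc2)nc1-c1ccc(C(F)(F)F)cc1`, gives 80% in this assay; the two readings sit level at the digits reported, inside the scatter of the method, and no single-point step connects them, so the pair says nothing about direction.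

Compound 3 `O=C(O)Cc1sc(C(c2ccc(F)cc2)c2ccc(F)cc2)nc1-c1ccnc(O)c1` has not yet been run in this assay. It differs from compound 1 in one place: hydroxy in place of pyrrolidin-1-yl on an aromatic carbon. Read one bond further out, the change runs from 2-(pyrrolidin-1-yl)pyridin-4-yl to 2-hydroxypyridin-4-yl, with the new group next to the ring nitrogen and meta to a large group on that ring.

Going by the values given here, no measured step of this kind exists in the set, so the size of the step from compound 1 to compound 3 must be estimated. The expectation is for a modest move downward, at or only just beyond the scatter, a number 10 percentage points lower from compound 1 to compound 3 (within the scatter), with the maximal response of compound 3 estimated at 70% in this assay, within a range from 40% to 95%.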

Compound 3, largest response reached (reported as efficacy), in percent of the reference or control that the assay uses: 60%
Beside the measured number, compound 3's estimate is 10 percentage points above it; the measured number falls inside the stated range.
By their numbers in this assay, from the lowest: compound 3; then compounds 1 and 2 (each within the scatter of the next).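

In this assay, for the compounds shown here, hydroxy in place of pyrrolidin-1-yl on this aromatic carbon, next to the ring nitrogen, gives a number 20 percentage points lower from compound 1 to compound 3 (beyond the scatter), the first step that can be read for direction. The maximal response therefore depends on the group held at this position: it is not the same with pyrrolidin-1-yl, a five-membered non-aromatic ring of 5 heavy atoms with 0 hydrogen-bond donors, as with hydroxy, a single heavy atom with 1 hydrogen-bond donor. No accompanying data tie the step to any one of these differences.

Because ring, size and donor count all change together in this one step, the compounds shown leave open which of them goes with the lower response; methoxy and dimethylamino at the same position would pull these differences apart. Also open, on these data alone, is whether a step of this size holds when the rest of the molecule differs, as it would with a piperidin-1-yl or morpholin-4-yl group on a changed core.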